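Amide substituent change on a quinoline carboxylic acid series

The compounds below may be only part of what the source reports. "The series", "measured", "known", "first", "only" and "open" are said of these compounds alone.

Measured so far:
compound 1 `COc1cc(-c2cc(C(=O)O)c3ccccc3n2)ccc1OCC(=O)Nc1cccc(Cl)c1` gives 2.3
compound 2 `COc1cc(-c2cc(C(=O)O)c3ccccc3n2)ccc1OCC(=O)Nc1ccc(Cl)cc1` gives 1.5

In a physicochemical assay for lipophilicity, using the shake flask method, in phosphate buffer, measured as octanol-water partition, at pH 7.4 (a higher number here means a more lipophilic compound, a lower number a more polar compound), compound 2 stands lowest of the two numbers, with compound 1 the nearest and higher; the step of a number 0.80 log units lower from compound 1 to compound 2 (beyond the scatter) lies beyond the scatter. Compound 3 `COc1cc(-c2cc(C(=O)O)c3ccccc3n2)ccc1OCC(=O)NCc1ccco1` differs from compound 2 by (furan-2-yl)methyl in place of 4-chlorophenyl on an amide-type nitrogen. Within the data shown here, no measured step covers this change; the only step seen swaps one chlorophenyl for another. For compound 3 the expected step is a number 0.80 log units lower from compound 2 to compound 3 (beyond the scatter), downward. Compound 3 is estimated at 0.7, within 0 to 1.4.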

Compound 3, distribution coefficient: -0.3
Estimate against measurement, compound 3: 1.00 log units above; measured number below the stated range.
By their numbers in this assay, from the lowest: compound 3; then compound 2; then compound 1.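

In this assay the amide-type nitrogen now carries a group other than a chlorophenyl, and the shift is large in both comparisons: a number 1.80 log units lower from compound 2 to compound 3 (beyond the scatter) and a number 2.60 log units lower from compound 1 to compound 3 (beyond the scatter). So this position can move the number much further than the shift of chlorine around the phenyl ring did in a number 0.80 log units lower from compound 1 to compound 2 (beyond the scatter). Nothing available explains the size of this drop.

The change replaces the ring and adds a methyl link in one step, so the two cannot be separated. A benzyl group on the same nitrogen would stand between them.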